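Bromo for methyl on a benzylsulfanyl arm

The source may hold more compounds than are shown below. What is called first, only, known or untested is meant among the compounds shown, and "the series" means these compounds.

The study concerns three measured compounds and one awaiting measurement in a functional assay on DU-145 cells (Homo sapiens) for inhibition, read by trypan blue exclusion, with a stated time of 96 h; on this read-out higher numbers stand for weaker inhibition of growth and lower numbers for stronger inhibition of growth. Compound 1 `COc1ccc(/C=C(/Sc2ccc(Br)cc2)C(=O)c2ccc(Br)cc2)cc1` gives 25000 nM, and compound 2 `COc1ccc(/C=C(/Sc2ccc(C)cc2)C(=O)c2ccc(Br)cc2)cc1` gives 50000 nM. Compound 3 `Cc1ccc(CS/C(=C/c2ccc(F)c([N+](=O)[O-])c2)C(=O)c2ccc(Cl)c([N+](=O)[O-])c2)cc1` gives 1000 nM, which stands as the lowest of the three numbers, beyond the scatter from both others. How the core of compound 3 differs from the core of compound 2 is not broken down here.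

Compound 4 `O=C(/C(=C\c1ccc(F)c([N+](=O)[O-])c1)SCc1ccc(Br)cc1)c1ccc(Cl)c([N+](=O)[O-])c1` is yet to be measured. It differs from compound 3 by bromo in place of methyl on an aromatic carbon. The same change is seen between two measured compounds: compound 1 differs from compound 2 by bromo in place of methyl on an aromatic carbon, and that step gave a 2.0-fold lower number from compound 2 to compound 1 (0.30 log units; within the scatter). The place of the change is described in the same words in both pairs, so the two are taken as the same change, though the longer names around it read benzylsulfanyl in the one case and sulfanyl in the other.

Since the earlier step stayed within the scatter, compound 4 is expected to lie close to compound 3, with a step of a 1.4-fold lower number from compound 3 to compound 4 (0.15 log units; within the scatter). Compound 4 is therefore estimated at 700 nM, between 250 nM and 2500 nM.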

Compound 4, concentration for 50% growth inhibition: > 100000 nM
Compound 4 ended at the assay's limit (the forecaster's own chance of this, stated with the estimate: 5%); middle value at least 140-fold (2.15 log units) away from the limit.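

In this assay the change from methyl to bromo did not carry from one core to the other, and the two steps differ in both size and direction: the same change on two cores in this assay, a 2.0-fold lower number (0.30 log units; within the scatter) from compound 2 to compound 1 and an at least 100-fold higher number (2.00 log units; beyond the scatter) from compound 3 to compound 4, at least 200-fold (2.30 log units) apart, beyond the scatter of two such steps

Compound 4 gives > 100000 nM, which is a limit of the assay and not a number. The pair on the core of compound 3 gave an at least 100-fold higher number from compound 3 to compound 4 (2.00 log units; beyond the scatter), yet this one pair does not show whether the gap between the two steps belongs to the benzylsulfanyl arm, to some other part of the core, or to the two together, nor how the change would behave on a further core.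

The compounds shown leave open whether the drop on the core of compound 3 is specific to the 4-bromobenzyl group or would also follow with chloro, fluoro or methoxy in the same place. They also leave open how that core would respond to an amine or a carboxylic acid there, or to a longer chain joining the sulfur to the aromatic ring.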